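The compounds below may be only part of what the source reports. "The series", "measured", "known", "first", "only" and "open" are said of these compounds alone.

In a toxicity assay on Hepa-1c1c7 cells (Mus musculus) for inhibition (on this read-out lower numbers stand for stronger inhibition and higher numbers for weaker inhibition), compound 1 `CCCC(O)C#CC#CCO` gives > 50000 nM, which is a limit of the assay and not a number. Among the compounds with values here, compound 2 `CCCCCC(O)C#CC#CC(O)CCC` gives 19000 nM, the only actual number so far. Compound 3 `CCCCCCCCCC(O)C#CC#CC(O)CCC` differs from compound 2 by butyl in place of hydrogen on a saturated chain carbon, six bonds along the chain from an oxygen on a saturated carbon and a triple-bonded carbon, with the butyl six bonds along the chain from an oxygen on a saturated carbon and a triple-bonded carbon. Within the data shown here, the one measured guide is an at least 2.6-fold lower number from compound 1 to compound 2 (0.42 log units; beyond the scatter), where pentyl replaced hydrogen. As far as these compounds go, that step starts from the limit of > 50000 nM in this assay, at which 1 of the 2 values shown sits, so its full size remains open. Since compound 3 also gains a longer carbon chain, a further modest move towards stronger inhibition seems likely, though a single step sets no firm pattern. The expected change is a 2.7-fold lower number from compound 2 to compound 3 (0.43 log units; beyond the scatter) in this assay. For compound 3 the estimated value is 7000 nM, with an expected range of 2500 nM to 19000 nM.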

Compound 3, half-maximal inhibitory concentration: 30000 nM
The estimate for compound 3 lay 4.3-fold (0.63 log units) below the measured number; measured number above the stated range.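

In this assay, the new step is a 1.6-fold higher number from compound 2 to compound 3 (0.20 log units; within the scatter), so butyl in place of hydrogen on this saturated chain carbon leaves the two compounds indistinguishable on this read-out. The earlier change, pentyl in place of hydrogen, gave an at least 2.6-fold lower number from compound 1 to compound 2 (0.42 log units; beyond the scatter), so a change beyond the scatter on adding carbon to one chain does not carry over to this further lengthening. The earlier step also has an open size, since one end of it is a limit and not a number: the limit of > 50000 nM in this assay, at which 1 of the 3 values shown sits.

The compounds shown leave open what an amine or a carboxylic acid in place of the butyl would do in this assay. They also leave open whether a longer chain at this position would move the number beyond the scatter.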